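Bromo in place of the aryl ester at the shared core

This account rests on a few compounds, and the source may have more. Where it says the series, first, only, none or still open, it means among the compounds named here.

Measured compounds in a functional assay on DLD-1 cells (Homo sapiens) for cytotoxicity, with a stated time of 48 h; on this read-out lower numbers stand for stronger inhibition and higher numbers for weaker inhibition:
Compound 1, `CC(C)COc1ccc2oc(/C=C/[S+](C)[O-])cc(=O)c2c1`, gives 5000 nM.
Compound 2, `CCCC(=O)Oc1ccc2oc(/C=C/[S+](C)[O-])cc(=O)c2c1`, gives 8700 nM.
Compound 3, `CCCOc1ccc2oc(/C=C/[S+](C)[O-])cc(=O)c2c1`, gives 6200 nM.

Compound 2 has the highest of the three numbers in this assay, but its step to compound 3, a 1.4-fold lower number from compound 2 to compound 3 (0.15 log units; within the scatter), and its step from compound 1, a 1.7-fold higher number from compound 1 to compound 2 (0.24 log units; within the scatter), both stay within the scatter, so no ordering among the three can be read from these values. The remaining step, a 1.2-fold higher number from compound 1 to compound 3 (0.09 log units; within the scatter), is likewise within the scatter. All three measured changes concern the group carried on the oxygen at the aromatic ring, and none of them moved the number beyond the scatter.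

Compound 4, `C[S+]([O-])/C=C/c1cc(=O)c2cc(Br)ccc2o1`, differs from compound 2 as follows: bromo in place of (propylcarbonyl)oxy on an aromatic carbon. For the measured compounds named here, this change removes the oxygen-linked group altogether rather than varying it, so no measured step bears on it directly. Going by the values given here, the measured steps show only that the series is flat with respect to this position so far. On that basis the expected step of a 1.2-fold lower number from compound 2 to compound 4 (0.09 log units; within the scatter) is none beyond the scatter, with wide uncertainty because no halogen is represented among the measured compounds. Compound 4 is therefore estimated at 7000 nM in this assay, with a range from 2500 nM to 20000 nM.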

Compound 4, half-maximal inhibitory concentration: 4500 nM
Compound 4: middle estimate off by 1.6-fold (0.19 log units), on the high side; the range from low to high includes it.
By their numbers in this assay, from the lowest: compounds 4, 1, 3 and 2 (each within the scatter of the next).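

Bromo on this aromatic carbon, a single heavy atom with no hydrogen-bond acceptors, stays within the scatter of each oxygen-linked group it replaces in this assay: a 1.9-fold lower number from compound 2 to compound 4 (0.29 log units; within the scatter), a 1.4-fold lower number from compound 3 to compound 4 (0.14 log units; within the scatter), and a 1.1-fold lower number from compound 1 to compound 4 (0.05 log units; within the scatter). The earlier compounds shown here varied only the group carried on the oxygen, whereas these steps show that, across the four compounds, the oxygen link itself is not needed to keep the number within this range, whether the group replaced is (propylcarbonyl)oxy, propoxy or isobutoxy. No supporting data are available to explain this flat result.

From the compounds shown here alone, it remains open whether any group on this aromatic carbon can move the number beyond the scatter, such as an amine, a carboxylic acid, or a chloro or plain hydrogen in place of bromo. A much longer chain on the oxygen is also untested among the compounds shown, as is whether the same flat picture holds on cells other than those of this assay.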